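Bromo to methyl: from compound 3 to compound 4

The source may hold more compounds than are shown below. What is called first, only, known or untested is meant among the compounds shown, and "the series" means these compounds.

Among the compounds with values here, compound 3 `Oc1ccccc1/C=N/c1nnc(SCc2nnc(-c3ccc(Br)cc3)o2)s1` gives 8320 nM in a functional assay on MCF7 cells (Homo sapiens) for inhibition, read by CCK-8 assay (a lower number here means a stronger inhibitor, a higher number a weaker inhibitor), and stands at the low end of the three numbers so far. Compound 1 `Oc1ccccc1/C=N/c1nnc(SCc2nnc(-c3ccccc3)o2)s1` gives 9760 nM and compound 2 `Oc1ccccc1/C=N/c1nnc(SCc2nnc(-c3ccccc3Cl)o2)s1` gives 18100 nM. The step of a 1.2-fold lower number from compound 1 to compound 3 (0.07 log units; within the scatter) is within the scatter, while a 2.2-fold lower number from compound 2 to compound 3 (0.34 log units; beyond the scatter) is modest. Compound 4 `Cc1ccc(-c2nnc(CSc3nnc(/N=C/c4ccccc4O)s3)o2)cc1` carries methyl in place of bromo on an aromatic carbon. Within the data shown here, only the bromo-for-hydrogen step bears on this, and it moved little, as a 1.2-fold lower number from compound 1 to compound 3 (0.07 log units; within the scatter) shows; no measured step contains a methyl. The expectation for this assay is therefore no step beyond the scatter, with a 1.1-fold higher number from compound 3 to compound 4 (0.03 log units; within the scatter) as the estimated change. Compound 4 is estimated at 9000 nM, within a range from 4000 nM to 20000 nM.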

Compound 4, half-maximal inhibitory concentration: 8750 nM
For compound 4 the middle estimate is 1.0-fold (0.01 log units) above the measured one, within the range that was stated.
By their numbers in this assay, from the lowest: compounds 3, 4, 1 and 2 (each within the scatter of the next, the first and the last beyond it).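

In this assay, methyl and bromo on this para ring carbon cannot be told apart (a 1.1-fold higher number from compound 3 to compound 4 (0.02 log units; within the scatter)), and methyl in place of hydrogen also stays within the scatter (a 1.1-fold lower number from compound 1 to compound 4 (0.05 log units; within the scatter)). The 4-methylphenyl group thus joins 4-bromophenyl in keeping a modest gap from 2-chlorophenyl (a 2.1-fold lower number from compound 2 to compound 4 (0.32 log units; beyond the scatter)), a step that changes both the group and its place. No measured evidence bears on why these values sit together.
As far as these compounds go, whether an amine or a carboxylic acid at this position would move the number beyond the scatter remains open.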